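This account rests on a few compounds, and the source may have more. Where it says the series, first, only, none or still open, it means among the compounds named here.

Measured compounds:
Compound 1 `COc1cc(Cl)cc(-c2nn(-c3cccc(NC(=O)c4ccc(Cl)c(Cl)c4)c3)cc2-c2ccncc2)c1` gives 71.6% in a functional assay on SNB-19 cells (Homo sapiens) for inhibition, read by sulforhodamine B assay, with a stated time of 48 h, tested at 10 uM; on this read-out higher numbers stand for a weaker effect at the one concentration tested and lower numbers for a stronger effect.
Compound 2 `COc1cc(Cl)cc(-c2nn(-c3cccc(NC(=O)Nc4cc(C(F)(F)F)cc(C(F)(F)F)c4)c3)cc2-c2ccncc2)c1` gives 26.1% in this assay.
Compound 3 `COc1cc(Cl)cc(-c2nn(-c3cccc(NC(=O)Nc4ccc(Cl)c(Cl)c4)c3)cc2-c2ccncc2)c1` gives 17.8% in this assay.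

Compound 1 stands highest of the three numbers in this assay: compound 2 lies nearest, and compound 3 furthest, both beyond the scatter. Among the compounds with values here, the one step that is measured runs a number 53.8 percentage points lower from compound 1 to compound 3 (beyond the scatter), an exchange of the linker rather than of the aryl group. Compound 4 `COc1cc(Cl)cc(-c2nn(-c3cccc(NC(=O)c4cccc(C(F)(F)F)c4)c3)cc2-c2ccncc2)c1` keeps the amide of compound 1 and differs only in the aryl group on the carbonyl carbon: 3-(trifluoromethyl)phenyl in place of 3,4-dichlorophenyl on a carbonyl carbon. Within the data shown here, no measured step bears on this change; compounds 2 and 3, which carry different aryl groups on a urea, show values that lie within the scatter of one another. Compound 4 is therefore expected to stay close to compound 1, a number 3.6 percentage points lower from compound 1 to compound 4 (within the scatter), with no step beyond the scatter. The estimate for compound 4 is 68%, from 45% to 90%.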

Compound 4, a percentage reported as activity, at one concentration (the size of the read-out at that concentration, not a potency): 82.2%
Beside the measured number, compound 4's estimate is 14.2 percentage points below it; low and high end bracket the measured number.
By their numbers in this assay, from the lowest: compounds 3 and 2 (each within the scatter of the next); then compound 1; then compound 4.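

In this assay, the aryl group on the carbonyl carbon of the amide matters in its own right: 3-(trifluoromethyl)phenyl in place of 3,4-dichlorophenyl gives a number 10.6 percentage points higher from compound 1 to compound 4 (beyond the scatter), a modest weakening of the effect. This change is much smaller than the one that separates the amide from the urea bearing (3,4-dichlorophenyl)amino, a number 64.4 percentage points higher from compound 3 to compound 4 (beyond the scatter). Nothing measured here explains either step. The compounds shown leave open whether these two aryl groups keep the same order on a urea, and how a carboxylic acid or an amine on the aryl group would read.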